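Methoxy for Methyl on a Carbonyl Carbon

This account rests on a few compounds, and the source may have more. Where it says the series, first, only, none or still open, it means among the compounds named here.

In an ADME assay for permeability, using PAMPA, at pH 7.4 (on this read-out lower numbers stand for lower permeability and higher numbers for higher permeability), compound 1 `CC(=O)c1ccc(NC(=O)Nc2cc(C)nc3ccccc23)cc1` gives 473 10^-6 cm/s, compound 2 `COc1ccc(NC(=O)Nc2cc(C)nc3ccccc23)cc1OC` gives 552 10^-6 cm/s and compound 3 `Cc1cc(NC(=O)Nc2ccc(F)c(F)c2)c2ccccc2n1` gives 478 10^-6 cm/s. These three values lie within the usual scatter of repeated measurements, so compound 1 cannot be told apart from the other two. Compound 4 `COC(=O)c1ccc(NC(=O)Nc2cc(C)nc3ccccc23)cc1` has not yet been measured. It differs from compound 1 in one place: methoxy in place of methyl on a carbonyl carbon. This puts methoxy in place of methyl on a carbonyl carbon, turning acetyl into methoxycarbonyl. Among the measured compounds shown here, no measured pair shows this change, so the expectation starts from compound 1 at 473 10^-6 cm/s, and no step beyond the scatter is expected in this assay. The expected change is small, a 1.1-fold higher number from compound 1 to compound 4 (0.02 log units; within the scatter). For compound 4 the estimated value is 500 10^-6 cm/s, with an expected range from 300 10^-6 cm/s to 760 10^-6 cm/s.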

Compound 4, apparent permeability: 448 10^-6 cm/s
For compound 4 the middle estimate is 1.1-fold (0.05 log units) above the measured one; the measured number falls inside the stated range.
By their numbers in this assay, from the lowest: compounds 4, 1, 3 and 2 (each within the scatter of the next).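

Methoxy in place of methyl on a carbonyl carbon, turning acetyl into methoxycarbonyl, gives the first pair here that differs in one place, and in this assay it reads as a 1.1-fold lower number from compound 1 to compound 4 (0.02 log units; within the scatter), so this change leaves the read-out within its usual noise. At this position, the hydrogen-bond acceptor that methoxy carries and methyl lacks comes with no step beyond the scatter. No measurement available here accounts for this result. On these data alone, whether an amino or a hydroxyl group on the same carbonyl carbon would behave alike stays open.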